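The source may hold more compounds than are shown below. What is called first, only, known or untested is meant among the compounds shown, and "the series" means these compounds.

Measured in a functional assay for inhibition, with Homo sapiens as the target; a lower number here means a stronger inhibitor, a higher number a weaker inhibitor:
- compound 1 `CC1(c2ccc(C(=N)N)cc2)NC(=O)N(CC(=O)NC(CC(=O)O)c2ccccc2)C1=O`: 200 nM
- compound 2 `C[C@@]1(c2ccc(C(=N)N)cc2)NC(=O)N(CC(=O)N[C@H](CC(=O)O)c2ccccc2)C1=O`: 50000 nM

Compound 2, at 50000 nM, stands highest of the two numbers. Compound 3 `C[C@]1(c2ccc(C(=N)N)cc2)NC(=O)N(CC(=O)N[C@H](CC(=O)O)c2ccccc2)C1=O` differs from it as follows: the two compounds have the same atoms and bonds; at least one stereo element is drawn with a configuration in one of them and without one in the other: 1 of 3 stereo elements differ; a stereocentre at a saturated ring carbon is drawn S in compound 2 and R in compound 3. Among the measured compounds shown here, one measured step bears on this, and it is large: a 250-fold higher number from compound 1 to compound 2 (2.40 log units; beyond the scatter). That step goes with the fact that one of compounds 1 and 2 is drawn with a defined configuration and the other without, at the place where they differ. Compound 1 has no configuration drawn at this ring carbon, so its 200 nM may include a form stronger than compound 2. A large step to a lower number is therefore expected in this assay, namely a 630-fold lower number from compound 2 to compound 3 (2.80 log units; beyond the scatter). Compound 3 is estimated at 80 nM, with an expected range of 15 nM to 1000 nM.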

Compound 3, half-maximal inhibitory concentration: 5000 nM
Compound 3: middle estimate off by 63-fold (1.80 log units), on the low side, and the stated range ends below it.
By their numbers in this assay, from the lowest: compound 1; then compound 3; then compound 2.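

With the chain carbon drawn R in both, changing the saturated ring carbon from S to R alone gives a 10-fold lower number from compound 2 to compound 3 (1.00 log units; beyond the scatter) in this assay, so the configuration at this carbon counts by itself. That gain is modest, and a 25-fold higher number from compound 1 to compound 3 (1.40 log units; beyond the scatter) shows that the R ring carbon does not by itself recover the number of the undrawn mixture. Both forms with the chain carbon drawn R therefore stand above compound 1.

Which form gives the low number of compound 1 stays open, including forms with the chain carbon drawn S. How an ethyl group on the saturated ring carbon would read is also open.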